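A few compounds are considered here, and "the series" means these few. Any claim that something is new, unique, unknown or untested is made for them only; others in the source may bear on it.

Compound 1 `CC1(c2ccccc2)CC(=O)N(CC(=O)N2CCN(c3ccccc3)CC2)C1=O` is the starting point here. Going by the values given here, in a functional assay on the whole organism (strain CD-1) with Mus musculus as the target, in the maximal electroshock model, with a stated time of 0.5 h (on this read-out lower numbers stand for an effect already at smaller amounts and higher numbers for an effect only at larger amounts of compound), compound 1 gives 300 mg/kg, the highest of the three numbers measured so far. Two close relatives carry a single fluoro on the outer ring: compound 2 `CC1(c2ccccc2)CC(=O)N(CC(=O)N2CCN(c3ccc(F)cc3)CC2)C1=O` gives 100 mg/kg and compound 3 `CC1(c2ccccc2)CC(=O)N(CC(=O)N2CCN(c3ccccc3F)CC2)C1=O` gives 100 mg/kg. Both changes helped by about the same amount: a 3.0-fold lower number from compound 1 to compound 2 (0.48 log units; beyond the scatter) and a 3.0-fold lower number from compound 1 to compound 3 (0.48 log units; beyond the scatter), while between the two fluoro positions there was no change at the digits printed from compound 2 to compound 3 (within the scatter).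

Compound 4 `CC1(c2ccccc2)CC(=O)N(CC(=O)N2CCN(c3ncccn3)CC2)C1=O` alters the same outer ring in a different way: pyrimidin-2-yl in place of phenyl on an amine nitrogen in a ring. Among the compounds with values here, no measured step swaps ring carbons for nitrogens, so the steps from compound 1 to compound 2 and from compound 1 to compound 3 bear on it only loosely, by showing that this ring tolerates change and that modest gains are possible there. A small step toward a lower number, or none beyond the scatter, is therefore expected, amounting to a 1.5-fold lower number from compound 1 to compound 4 (0.18 log units; within the scatter). For compound 4 the estimate in this assay is 200 mg/kg, with a range from 100 mg/kg to 600 mg/kg.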

Compound 4, minimum effective dose: "not active" (no number reported)
Compound 4: no number reported; the estimate stays without a comparison.
By their numbers in this assay, from the lowest: compounds 2 and 3 (each within the scatter of the next); then compound 1.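

In this assay, going by these compounds alone, compound 4 is reported as "not active" without a number, so no step from compound 1 or any other compound to it can be read. Nothing available explains this result. As far as these compounds go, how far compound 4 lies from compound 1 on this scale stays open.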